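Trading a ring for an open chain at the amide tail

A few compounds are considered here, and "the series" means these few. Any claim that something is new, unique, unknown or untested is made for them only; others in the source may bear on it.

Of the compounds shown here, three of a shared core have been tested so far. Compound 1 `Cc1oc(-c2ccc(Cl)cc2)nc1CN1CCC(C(=O)NCCCN2C[C@H](C)C[C@H](C)C2)CC1` gives 11500 nM in an ADME assay on Huh7.5.1 cells (Homo sapiens) for cytotoxicity, read by ATP content, with a stated time of 48 h; on this read-out lower numbers stand for higher toxicity in this test and higher numbers for lower toxicity in this test. Compound 2 `Cc1ccccc1-c1nc(CN2CCC(C(=O)NCCCN3CCC(C)CC3)CC2)c(C)o1` gives 12300 nM in this assay, and compound 3 `Cc1oc(-c2c(Cl)cccc2Br)nc1CN1CCC(C(=O)NCCCN2C[C@H](C)C[C@H](C)C2)CC1` gives 12200 nM in this assay. Among the measured compounds shown here, the only single-point step among them, a 1.1-fold higher number from compound 1 to compound 3 (0.03 log units; within the scatter), stays within the scatter. Compound 2 holds the highest of the three numbers, but its gaps to compound 3 and to compound 1 are both within the scatter, so nothing separates the three.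

Compound 4 `CCCN(CCC)CCNC(=O)C1CCN(Cc2nc(-c3ccccc3C)oc2C)CC1` differs from compound 2 in one place: dipropylamino in place of (4-methylpiperidin-1-yl)methyl on a saturated chain carbon, two bonds along the chain from an amide-type nitrogen. For the measured compounds named here, no measured step touches this end of the molecule; the one step available changes the aromatic ring on the far side and is itself within the scatter. With only a flat picture to lean on, the author expects compound 4 to give 12000 nM in this assay, with a range from 6000 nM to 24000 nM. The step of a 1.0-fold lower number from compound 2 to compound 4 (0.01 log units; within the scatter) is thus expected to stay within the scatter.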

Compound 4, half-maximal cytotoxic concentration: 30500 nM
Compound 4: middle estimate off by 2.5-fold (0.41 log units), on the low side; the whole stated range lies below it.
By their numbers in this assay, from the lowest: compounds 1, 3 and 2 (each within the scatter of the next); then compound 4.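

In this assay, the change from 3-(4-methylpiperidin-1-yl)propyl to 2-(dipropylamino)ethyl gives a 2.5-fold higher number from compound 2 to compound 4 (0.39 log units; beyond the scatter), which is the first step shown to pass beyond the scatter. Among the compounds shown here, the amide tail can therefore move this number, and in the direction of lower toxicity in this test, whereas the one earlier step, a 1.1-fold higher number from compound 1 to compound 3 (0.03 log units; within the scatter), changed an aromatic substituent and stayed within the scatter. Nothing available accounts for the rise.

This single step removes the ring and shortens the chain to the tail amine together, so the compounds shown cannot separate the two changes; a 3-(dipropylamino)propyl tail would bear directly on that. From the compounds shown here alone, it also remains open whether the same exchange would have a similar effect alongside the 4-chlorophenyl group of compound 1, or whether a smaller open amine such as diethylamino would do the same.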